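The source may hold more compounds than are shown below. What is called first, only, known or untested is meant among the compounds shown, and "the series" means these compounds.

Series notes. Among the measured compounds shown here, compound 2 `Nc1ccccc1NC(=O)c1ccc(COCNc2nc(Nc3ccccc3)c3ncn(C4CCCC4)c3n2)cc1` gives 56.1% in a functional assay on NCI-H460 cells (Homo sapiens) for antiproliferative activity, read by CCK-8 assay, with a stated time of 72 h, tested at 8 uM (on this read-out higher numbers stand for a stronger effect at the one concentration tested and lower numbers for a weaker effect), the highest of the three numbers measured so far, though its margin over compound 3 lies within the scatter. Compound 3 `CCCCn1cnc2c(Nc3ccccc3)nc(NCOCc3ccc(C(=O)Nc4ccccc4N)cc3)nc21` gives 51.3% in this assay, and compound 1 `CC(C)n1cnc2c(Nc3ccccc3)nc(NCOCc3ccc(C(=O)Nc4ccccc4N)cc3)nc21` gives 34.3%. The two steps that go beyond the scatter both concern the group on the aromatic nitrogen: a number 21.8 percentage points higher from compound 1 to compound 2 (beyond the scatter), and a number 17 percentage points higher from compound 1 to compound 3 (beyond the scatter), whereas a number 4.8 percentage points lower from compound 2 to compound 3 (within the scatter).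

Compound 4 `Nc1ccccc1NC(=O)c1ccc(COCNc2nc(Nc3ccc(-c4ccccc4)cc3)c3ncn(C4CCCC4)c3n2)cc1` differs from compound 2 by phenyl in place of hydrogen on an aromatic carbon. None of the measured steps touches this position; all three vary only the group on the aromatic nitrogen, so a phenyl entering on the aromatic carbon para to a large group has no precedent in the series, and the direction of its effect cannot be read from the steps shown. The expectation therefore rests on compound 2 alone, whose 56.1% serves as the anchor, with a wide range to reflect the missing precedent. Compound 4 is estimated at 55% in this assay, between 25% and 80%, which means an expected step of a number 1.1 percentage points lower from compound 2 to compound 4 (within the scatter), within the scatter.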

Compound 4, a percentage reported as inhibition, at one concentration (the size of the read-out at that concentration, not a potency): 41.6%
The estimate for compound 4 lay 13.4 percentage points above the measured number, and the stated range covers the measured number.
By their numbers in this assay, from the lowest: compounds 1, 4, 3 and 2 (each within the scatter of the next, the first and the last beyond it).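

Phenyl in place of hydrogen on the aromatic carbon para to a large group, the first change away from the aromatic nitrogen, gives a number 14.5 percentage points lower from compound 2 to compound 4 (beyond the scatter) in this assay, so the read-out is sensitive to more than the group on that nitrogen. With cyclopentyl held constant on the aromatic nitrogen, this gain of 6 heavy atoms, all carbon, weakens the effect at the tested concentration without abolishing it, as compound 4 still gives 41.6%. The compounds shown offer no measurement that accounts for this step.

From the compounds shown here alone, whether a methoxy group, a chlorine atom or an amine on the same aromatic carbon would preserve the number of compound 2 remains open, as does whether a smaller carbon group such as methyl would give a step in the same direction. Also open, going by these compounds, is whether phenyl at this position would have a similar effect with butyl or isopropyl on the aromatic nitrogen, and because the read-out comes from a single concentration, the step does not establish a change in potency.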